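A few compounds are considered here, and "the series" means these few. Any claim that something is new, unique, unknown or untested is made for them only; others in the source may bear on it.

Measured compounds:
Compound 1, `COc1ccc(C(=O)Nc2ncc(-c3ccc(OC)cc3)n2C)cc1`: in a toxicity assay on THP-1 cells (Homo sapiens) for inhibition (a higher number here means that more compound is tolerated, a lower number that less compound is tolerated), compound 1 gives > 100000 nM.
Compound 2, `COc1ccc(-c2cnc(NC(=O)c3cccc(Br)c3)n2C)cc1`: in this assay compound 2 gives > 100000 nM.

Both of these values are limits of the assay, not numbers. Among the measured compounds shown here, for compound 1 the value > 100000 nM means only that the compound was tolerated up to the highest concentration tested. For compound 2 the value > 100000 nM is likewise a limit and no number. For the measured compounds named here, the single measured step, a step that the two limits leave unreadable from compound 1 to compound 2, therefore cannot be read, as both of its ends sit at the same limit (the limit of > 100000 nM in this assay, at which 2 of the 2 values shown sit). Compound 2 thus stands at the top of what this assay can report, and nothing separates it from compound 1.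

Compound 3, `COc1ccc(-c2cnc(NC(=O)c3cccc(F)c3)n2C)cc1`, has not yet been measured. It differs from compound 2 in one place: fluoro in place of bromo on an aromatic carbon. Going by the values given here, the only measured step, a step that the two limits leave unreadable from compound 1 to compound 2, gives no readable size, so there is no measured guide to how much a change on this group can shift the result. With both measured compounds tolerated up to the limit, no step beyond the scatter is expected in this assay in either direction. Compound 3 is therefore estimated at 100000 nM, within 30000 nM to 300000 nM. The step this expectation implies, a number no higher from compound 2 to compound 3 (the limit leaves the size open), is expected to lie within the scatter, with a limit the most likely outcome.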

Compound 3, half-maximal cytotoxic concentration: > 100000 nM
Compound 3 ended at the assay's limit (the forecaster's own chance of this, stated with the estimate: 80%); the middle value sits exactly at the limit.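

The steps linking compound 1, compound 2 and compound 3 cannot be read, because all three compounds end at the same limit, which is not a number: the limit of > 100000 nM in this assay, at which 3 of the 3 values shown sit.

The compounds shown leave open what concentration, if any, would harm these cells, and whether changing the group on the carbonyl carbon can shift the result in this assay at all.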